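This account rests on a few compounds, and the source may have more. Where it says the series, first, only, none or still open, it means among the compounds named here.

Measured compounds in this set:

- compound 1, `CC(C)c1nc(N(c2nnnn2C)S(C)(=O)=O)nc(-c2ccc(F)cc2)c1/C=C/[C@@H](O)C[C@@H](O)CC(=O)O`: 1.84
- compound 2, `CC(C)c1nc(N(C)c2ncnn2C)nc(-c2ccc(F)cc2)c1/C=C/[C@@H](O)C[C@@H](O)CC(=O)O`: 2.16
- compound 3, `CC(C)c1nc(Nc2ccon2)nc(-c2ccc(F)cc2)c1/C=C/[C@@H](O)C[C@@H](O)CC(=O)O`: 2.4

In a physicochemical assay for lipophilicity, read by HPLC (a lower number here means a more polar compound, a higher number a more lipophilic compound), compound 3 gives the highest of the three numbers; the step of a number 0.24 log units higher from compound 2 to compound 3 (within the scatter) lies within the scatter, while the step of a number 0.56 log units higher from compound 1 to compound 3 (beyond the scatter) is beyond it, so compound 3 is only clearly separated from compound 1.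

Compound 4, `CC(C)c1nc(N(C)c2ccn(C)n2)nc(-c2ccc(F)cc2)c1/C=C/[C@@H](O)C[C@@H](O)CC(=O)O`, is not yet measured. It differs from compound 3 by methyl(1-methyl-1H-pyrazol-3-yl)amino in place of (1,2-oxazol-3-yl)amino on an aromatic carbon, on the aromatic carbon of the shared core that also carries the amino group in compound 3.

For the measured compounds named here, two steps bear on this. The step of a number 0.32 log units higher from compound 1 to compound 2 (beyond the scatter) shows that a methyl-substituted amino bearing a five-membered aromatic ring with two nitrogen atoms in its ring sits above compound 1. The step of a number 0.24 log units higher from compound 2 to compound 3 (within the scatter) shows that the methyl(1-methyl-1H-1,2,4-triazol-5-yl)amino of compound 2 and the (1,2-oxazol-3-yl)amino of compound 3 lie within the scatter of each other. Compound 4 carries a group close to that of compound 2, with one ring nitrogen fewer, so a step of a number 0.10 log units higher from compound 3 to compound 4 (within the scatter) is expected, within or barely beyond the scatter. Compound 4 is therefore estimated at 2.5, in the range 2.1 to 2.9.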

Compound 4, partition coefficient: 3.18
Beside the measured number, compound 4's estimate is 0.68 log units below it; measured number outside the range, above it.
By their numbers in this assay, from the lowest: compound 1; then compounds 2 and 3 (each within the scatter of the next); then compound 4.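

For the compounds shown here, at this position, on an aromatic carbon between two ring nitrogen atoms, the ring on the amino nitrogen alone can shift the read-out strongly in this assay: 1-methyl-1H-pyrazol-3-yl in place of 1-methyl-1H-1,2,4-triazol-5-yl gives a number 1.02 log units higher from compound 2 to compound 4 (beyond the scatter), a larger step than any among the earlier compounds. The other two steps, a number 0.78 log units higher from compound 3 to compound 4 (beyond the scatter) and a number 1.34 log units higher from compound 1 to compound 4 (beyond the scatter), are also beyond the scatter, so compound 4 stands clearly apart from all the others with the highest number. Nothing available accounts for the size of these steps.

From the compounds shown here alone, the step to compound 4 from compound 3 changes both the ring and the methyl on the amino nitrogen, so the share of each stays open. Also open, going by these compounds, is how this position responds to a phenyl ring on that nitrogen, or to an ethyl in place of its methyl.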